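Sulfonylpiperidine series: phenyl in place of hydroxyethylpiperidinyl

A few compounds are considered here, and "the series" means these few. Any claim that something is new, unique, unknown or untested is made for them only; others in the source may bear on it.

Measured compounds:
compound 1 `Cc1cc(C)c(S(=O)(=O)N2CCC(N3CCC(C)CC3)CC2)c(C)c1` — 0.03 nM
compound 2 `Cc1cc(C)c(S(=O)(=O)N2CCC(N3CCC(CCO)CC3)CC2)c(C)c1` — 19 nM

Going by the values given here, in a functional assay on DLD-1 cells (Homo sapiens) for antiproliferative activity, read by CellTiter-Glo, with a stated time of 72 h (a lower number here means a stronger inhibitor, a higher number a weaker inhibitor), compound 2 stands at the higher end of the two numbers so far; its nearest neighbour is compound 1, and the step of a 630-fold higher number from compound 1 to compound 2 (2.80 log units; beyond the scatter) shows how strongly this position answers to a change. Compound 3 `Cc1cc(C)c(S(=O)(=O)N2CCC(c3ccccc3)CC2)c(C)c1` is unmeasured. It differs from compound 2 in phenyl in place of 4-(2-hydroxyethyl)piperidin-1-yl on a saturated ring carbon. Among the compounds with values here, no measured step covers a swap of this kind: the only step seen, from compound 1 to compound 2, changes the tail of the ring but keeps the ring itself, whereas here the whole ring with its nitrogen leaves and an aromatic ring of carbon only enters. The large size of that single step argues that a change of this scope is unlikely to pass within the scatter. For compound 3 a step of a 16-fold higher number from compound 2 to compound 3 (1.20 log units; beyond the scatter) in this assay is expected, toward a weaker inhibitor, with wide uncertainty. The estimate for compound 3 is 300 nM, within 15 nM to 6000 nM.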

Compound 3, half-maximal inhibitory concentration: > 5000 nM
Compound 3: a limit, no number (the forecaster's own chance of this, stated with the estimate: 20%); middle value at least 16-fold (1.22 log units) away from the limit.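

Compound 3 carries a limit of the assay, not a number: the limit of > 5000 nM in this assay, at which 1 of the 3 values shown sits.

In this assay, phenyl in place of 4-(2-hydroxyethyl)piperidin-1-yl on the saturated ring carbon gives an at least 260-fold higher number from compound 2 to compound 3 (2.42 log units; beyond the scatter), and phenyl in place of 4-methylpiperidin-1-yl gives an at least 160000-fold higher number from compound 1 to compound 3 (5.22 log units; beyond the scatter). The earlier step changed only the tail and kept the ring, whereas these steps show that this position also answers strongly when the whole ring with its nitrogen gives way to an aromatic ring of carbon only, with the full size of the loss hidden behind the limit.

Phenyl changes the ring and removes the nitrogen in one move, so the compounds shown do not separate the two changes. As far as these compounds go, whether cyclohexyl or an open-chain amine in this place would keep the potency of compound 1 remains open.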